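The source may hold more compounds than are shown below. What is called first, only, known or untested is meant among the compounds shown, and "the series" means these compounds.

Working notes on the series.

Compound 1 `COc1cc(-c2cc(/C=C/C(=O)c3ccc(N)cc3)[nH]n2)cc(OC)c1OC` and compound 2 `COc1ccc(C(=O)/C=C/c2cc(-c3cc(OC)c(OC)c(OC)c3)n[nH]2)cc1OC` share a core and differ only on the carbonyl carbon. In a functional assay on SK-MEL-5 cells (Homo sapiens) for cytotoxicity, read by sulforhodamine B assay, with a stated time of 48 h, tested at 1 uM (a lower number here means a stronger effect, a higher number a weaker effect of the compound at the concentration tested), compound 1 gives 90%. Going by the values given here, in the same read-out compound 2 gives 91%, which is the highest of the two numbers measured so far, with compound 1 as the nearest neighbour. Among the compounds with values here, the single measured step, a number 1 percentage points higher from compound 1 to compound 2 (within the scatter), is 3,4-dimethoxyphenyl in place of 4-aminophenyl on the carbonyl carbon and stays within the scatter.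

Compound 3 `COc1cc(C(=O)/C=C/c2cc(-c3cc(OC)c(OC)c(OC)c3)n[nH]2)cc(OC)c1OC` is not yet measured. It differs from compound 2 by methoxy in place of hydrogen on an aromatic carbon. Within the data shown here, no measured step touches this aromatic carbon, so the only bearing comes from the step from compound 1 to compound 2, which shows that reworking the groups on the carbonyl-side ring left the read-out essentially unchanged. On that basis no step beyond the scatter is expected for a number 2 percentage points lower from compound 2 to compound 3 (within the scatter), in either direction.

For compound 3 in this assay the expected value is 89%, with a range from 72% to 102%.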

Compound 3, a percentage reported as activity, at one concentration (the size of the read-out at that concentration, not a potency): 86%
Estimate against measurement, compound 3: 3 percentage points above; low and high end bracket the measured number.
By their numbers in this assay, from the lowest: compounds 3, 1 and 2 (each within the scatter of the next).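

In this assay, methoxy in place of hydrogen on this aromatic carbon, ortho to a methoxy group and meta to a large group, gives a number 5 percentage points lower from compound 2 to compound 3 (within the scatter), so this position accepts the added methoxy without a step beyond the scatter. Going by these compounds alone, this is the first reading at this aromatic carbon, and it joins a number 1 percentage points higher from compound 1 to compound 2 (within the scatter) as a second change on the carbonyl side of the shared core that does not separate the two compounds it links. Nothing at hand bears on why these changes leave the read-out within the scatter.

The compounds shown leave open whether an amine or a hydroxy group on this aromatic carbon, or a longer chain such as ethoxy in place of the added methoxy, would give a step beyond the scatter. They also leave open whether compound 2 and compound 3 would remain within the scatter of each other at a concentration other than the one tested, as a reading at one concentration gives no potency.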